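The source may report more compounds than this note shows. Statements on the series, on what has been measured and on what is new or still open speak of the compounds shown alone.

In an ADME assay on MDBK cells (Bos taurus) for cytotoxicity, read by MTT assay (on this read-out lower numbers stand for higher toxicity in this test and higher numbers for lower toxicity in this test), compound 3 `CC(C)(C)C(=O)N(CCCCCCN1C[C@H](O)[C@@H](O)[C@H](O)[C@H]1CO)C1CCCCC1` gives > 500000 nM, which is a limit of the assay and not a number. Compound 1 `OC[C@@H]1[C@@H](O)[C@H](O)[C@@H](O)CN1CCCCCCN(C1CCCCC1)C1CCCCC1` also reaches only a limit, > 500000 nM. Compound 2 `CC1CCCCC1N(CCCCCCN1C[C@H](O)[C@@H](O)[C@H](O)[C@H]1CO)C(=O)C(C)(C)C` likewise stops at a limit, > 500000 nM. The step that the two limits leave unreadable from compound 1 to compound 3 and the step that the two limits leave unreadable from compound 2 to compound 3 therefore cannot be sized, since all three compounds sit at the limit of > 500000 nM in this assay, at which 3 of the 3 values shown sit. Compound 4 `CC(C)(C)C(=O)N(CCCCCCN1C[C@H](O)[C@@H](O)[C@H](O)[C@H]1CO)c1ccc(F)cc1F` differs from compound 3 by 2,4-difluorophenyl in place of cyclohexyl on an amide-type nitrogen. Going by the values given here, no measured step reads on this change beyond the shared limit, so no movement beyond the scatter is expected in this assay. Compound 4 is accordingly estimated at 500000 nM, with a range from 150000 nM to 1500000 nM, and is expected to remain at a limit. The step this estimate means is expected to be a number no higher from compound 3 to compound 4 (the limit leaves the size open).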

Compound 4, half-maximal cytotoxic concentration: > 500000 nM
Compound 4: only a limit was reported (the forecaster's own chance of this, stated with the estimate: 80%); the middle value lies on the limit itself.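

No step from compound 2 or compound 3 to compound 4 can be read, because each compound's value is only a limit: the limit of > 500000 nM in this assay, at which 4 of the 4 values shown sit.

The compounds shown leave open how far the true values of compound 2, compound 3 and compound 4 lie past that limit, and whether they differ at all.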